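The compounds below may be only part of what the source reports. "The series", "measured", "known", "first", "only" and "open" are said of these compounds alone.

Of the compounds shown here, three of a shared core have been measured in a functional assay on L1210 cells (Mus musculus), with a stated time of 1 days; a higher number here means a more potent compound, by a factor of ten per unit of this negative logarithm, a lower number a less potent compound. Compound 1, `CC(=O)C1=C(N2CC2)C(=O)C(C)=C(N2CC2)C1=O`, gives 3.48 in that assay. Compound 2, `CC(C)C1=C(N2CC2)C(=O)C(C(C)C)=C(N2CC2)C1=O`, gives 4.14, and compound 3, `CCCC1=C(N2CC2)C(=O)C(CCOC(N)=O)=C(N2CC2)C1=O`, gives 4.42. Compound 1 thus stands lowest of the three numbers: compound 2 lies nearest to it, beyond the scatter, and compound 3 lies furthest from it, also beyond the scatter.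

The step now followed leads from compound 1 to compound 4, `COCCC1=C(N2CC2)C(=O)C(C)=C(N2CC2)C1=O`, which has not yet been measured. The change is 2-methoxyethyl in place of acetyl on a double-bonded ring carbon. It sits on a double-bonded ring carbon of the six-membered non-aromatic ring of carbon only, next to the ring atom that bears an aziridin-1-yl group.

Within the data shown here, no step between two measured compounds is available to guide this change directly. What the measured numbers show is that the two compounds whose ring carbons carry chains rather than an acetyl, compound 2 at 4.14 and compound 3 at 4.42, both lie above compound 1. On that basis a rise beyond the scatter is expected, and the estimated step is a number 0.62 log units higher from compound 1 to compound 4 (beyond the scatter). Compound 4 is therefore expected to give about 4.1, within a range of 3.6 to 4.6.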

Compound 4, logarithm of the reciprocal of the active concentration, log(1/C): 5.12
Estimate against measurement, compound 4: 1.02 log units below; the measured number lies above the stated range.
By their numbers in this assay, from the lowest: compound 1; then compounds 2 and 3 (each within the scatter of the next); then compound 4.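

In this assay, 2-methoxyethyl in place of acetyl on a double-bonded ring carbon gives a number 1.64 log units higher from compound 1 to compound 4 (beyond the scatter), a large step and the first here that can be read at a single place on the shared core, with the methyl group and both aziridin-1-yl groups unchanged. Neither group has a ring, a hydrogen-bond donor or a net charge, and their hydrogen-bond acceptor counts match, so what differs is the chain itself and the double bond outside aromatic rings that leaves with acetyl. No measurement is at hand that accounts for the size of this step.

The compounds shown leave open whether the rise belongs to the loss of acetyl or to the 2-methoxyethyl chain as such, a question on which a plain propyl chain, a 2-hydroxyethyl chain or a 2-aminoethyl chain at this place would bear. They also leave open whether the same exchange gives a step of similar size when an isopropyl group or a longer chain stands in place of the methyl group.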